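This account rests on a few compounds, and the source may have more. Where it says the series, first, only, none or still open, it means among the compounds named here.

Of the compounds shown here, three have been read in a functional assay on HaCaT cells (Homo sapiens) for cytotoxicity, with a stated time of 48 h; a higher number here means a weaker inhibitor, a lower number a stronger inhibitor. Compound 1 `COc1cc(O)c(C(=O)/C=C/c2ccc(F)cc2)c(OC)c1` gives only a limit, > 20000 nM. Compound 3 `COc1cc(O)c(C(=O)/C=C/c2ccccc2OC)c(OC)c1` gives 10900 nM. Compound 2 `COc1cccc(/C=C/C(=O)c2c(OC)cc(OC)cc2OC)c1` gives 5300 nM, the lower of the two actual numbers, and its gap to compound 3 lies just beyond the usual scatter.

Compound 4 `COc1cc(OC)c(C(=O)/C=C/c2ccc(F)cc2)c(OC)c1` is still unmeasured. Compared with compound 2, it carries 4-fluorophenyl in place of 3-methoxyphenyl on a double-bonded chain carbon bound to a double-bonded chain carbon. Going by the values given here, no measured pair isolates this change, so its size in this assay remains an expectation. A rise in the number, meaning a weaker inhibitor, is expected because compound 1 with its 4-fluorophenyl shows the limit > 20000 nM. That single compound supports only a modest move, near the edge of the scatter. The estimated step is a 1.9-fold higher number from compound 2 to compound 4 (0.28 log units; within the scatter). For compound 4 the expected value is 10000 nM, with an estimated range of 4000 nM to 20000 nM.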

Compound 4, half-maximal inhibitory concentration: 7600 nM
Compound 4: the middle estimate sits 1.3-fold (0.12 log units) above what was measured; the range from low to high includes it.
By their numbers in this assay, from the lowest: compounds 2, 4 and 3 (each within the scatter of the next, the first and the last beyond it). At a limit, above all of these: compound 1.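

In this assay, 4-fluorophenyl in place of 3-methoxyphenyl on a double-bonded chain carbon bound to a double-bonded chain carbon gives a 1.4-fold higher number from compound 2 to compound 4 (0.16 log units; within the scatter), so the two groups are not told apart at this position. Methyl in place of hydrogen on an oxygen on an aromatic ring gives an at least 2.6-fold lower number from compound 1 to compound 4 (0.42 log units; beyond the scatter), the first one-place step in the series that lies beyond the scatter. Its full size stays unknown because compound 1 is read only as a limit: the limit of > 20000 nM in this assay, at which 1 of the 4 values shown sits.

Going by these compounds, the methyl step rests on a single pair, so whether it holds with 3-methoxyphenyl on the chain remains open. Also open, on these data alone, is how an amine or a carboxylic acid on the phenyl ring at the chain end would read in this assay.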